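The source may hold more compounds than are shown below. What is called first, only, known or untested is meant among the compounds shown, and "the series" means these compounds.

Measured so far:
compound 1 `Oc1nnc(-c2cccnc2)c2ccccc12` — 26%
compound 2 `C=CCn1nc(-c2cccnc2)c2ccccc2c1=O` — 70%

In an assay on isolated protein (Oryctolagus cuniculus) with Thromboxane-A synthase (Homo sapiens) as the target, tested at 1 uM (on this read-out higher numbers stand for more inhibition at the one concentration tested (going by the name of the read-out) and lower numbers for less inhibition), compound 1 gives 26% and compound 2 gives 70%. Compound 2 stands highest of the two; compound 1 lies lower by a margin beyond the scatter. Compound 3 `COCCn1nc(-c2cccnc2)c2ccccc2c1=O` has not yet been measured in this assay. It differs from compound 2 by methoxymethyl in place of vinyl on a saturated chain carbon bound to an aromatic nitrogen. Among the measured compounds shown here, no measured pair shows this change, so its size is unknown; a modest loss, or no step beyond the scatter, is expected, with an estimated step of a number 10 percentage points lower from compound 2 to compound 3 (within the scatter). Compound 3 is expected to give 60%, in the range 35% to 85%.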

Compound 3, a percentage reported as inhibition, at one concentration (the size of the read-out at that concentration, not a potency): 55%
The estimate for compound 3 lay 5 percentage points above the measured number, and the stated range covers the measured number.
By their numbers in this assay, from the lowest: compound 1; then compound 3; then compound 2.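

In this assay the change of allyl to 2-methoxyethyl gives the first step read at this place, on a saturated chain carbon bound to an aromatic nitrogen: a number 15 percentage points lower from compound 2 to compound 3 (beyond the scatter) in this series. The vinyl end is therefore not required for inhibition, since compound 3 still gives 55% at the one concentration tested, although methoxymethyl does not match vinyl here. No available data account for the size of this step.

Open, on these data alone, is how a longer chain, an amine or a carboxylic acid would read at this place. A single step also leaves unsettled whether the loss belongs to the ether oxygen or to the chain as a whole.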